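From an ethyl to a butenyl chain on the ring nitrogen

The source may hold more compounds than are shown below. What is called first, only, known or untested is meant among the compounds shown, and "the series" means these compounds.

Compound 1, `OC1CCNCC1N1CCN(c2ccccc2)CC1`: in an assay on PC-12 cells for displacement of a labelled ligand from vesicular acetylcholine transporter (Homo sapiens) (a higher number here means a weaker inhibitor, a lower number a stronger inhibitor), compound 1 gives > 100 nM.
Compound 2, `CCN1CCC(O)C(N2CCN(c3ccccc3)CC2)C1`: in this assay compound 2 gives > 1000 nM.

Both values are limits of this assay, not numbers, so the step that the two limits leave unreadable from compound 1 to compound 2 cannot be read. Compound 2 thus stands only at a limit. Compound 3, `C/C=C/CN1CCC(O)C(N2CCN(c3ccccc3)CC2)C1`, differs from compound 2 by prop-1-en-1-yl in place of methyl on a saturated chain carbon bound to an amine nitrogen in a ring. Among the compounds with values here, no measured step gives a readable size for this change. Compound 3 is therefore expected to remain weak, and the step that the limit leaves unreadable from compound 2 to compound 3 is expected to stay within the scatter. Compound 3 is estimated at 3000 nM, in the range 500 nM to 30000 nM.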

Compound 3, half-maximal inhibitory concentration: > 100 nM
Compound 3 gave a limit, no number (the forecaster's own chance of this, stated with the estimate: 70%); the middle value is on the limit's open side.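

Within the data shown here, compound 1, compound 2 and compound 3 give only limits in this assay, not numbers, and no step among them can be read. As far as these compounds go, how strong an inhibitor each one is, and whether the but-2-en-1-yl chain changes that, stays open.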